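Furan-3-yl to pyridin-2-yl on the shared core

The source may report more compounds than this note shows. Statements on the series, on what has been measured and on what is new or still open speak of the compounds shown alone.

In a functional assay on HL-60 cells (Homo sapiens) for inhibition (on this read-out lower numbers stand for stronger inhibition and higher numbers for weaker inhibition), compound 1 (`OC[C@H]1OC(n2cnc3c(-c4ccco4)ncnc32)[C@H](O)[C@@H]1O`) gives 2700 nM while compound 2 (`OC[C@H]1OC(n2cnc3c(-c4cc[nH]c4)ncnc32)[C@H](O)[C@@H]1O`) gives 3200 nM and compound 3 (`OC[C@H]1OC(n2cnc3c(-c4ccoc4)ncnc32)[C@H](O)[C@@H]1O`) gives 3300 nM in the same read-out. Compound 3 therefore stands level with the other two, within the scatter.

The next change leads to compound 4 (`OC[C@H]1OC(n2cnc3c(-c4ccccn4)ncnc32)[C@H](O)[C@@H]1O`), with pyridin-2-yl in place of furan-3-yl on an aromatic carbon.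

Among the compounds with values here, three measured steps bear on this change: a 1.2-fold higher number from compound 1 to compound 2 (0.07 log units; within the scatter) and a 1.2-fold higher number from compound 1 to compound 3 (0.09 log units; within the scatter) and a 1.0-fold higher number from compound 2 to compound 3 (0.01 log units; within the scatter) all stay within the scatter. Each exchanges one five-membered aromatic ring for another. Within the data shown here, none brings in a six-membered aromatic ring, so the series offers no direct precedent and the range must stay wide.

No step beyond the scatter is expected in this assay, and the estimated step is a 1.1-fold higher number from compound 3 to compound 4 (0.03 log units; within the scatter) on this basis. For compound 4 the expected value is 3500 nM (estimated range 1200 nM to 10000 nM) in this read-out.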

Compound 4, half-maximal inhibitory concentration: 5600 nM
The estimate for compound 4 lay 1.6-fold (0.20 log units) below the measured number; the range from low to high includes it.
By their numbers in this assay, from the lowest: compounds 1, 2, 3 and 4 (each within the scatter of the next, the first and the last beyond it).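

In this assay, compound 4 shows that a six-membered aromatic ring can stand at this position with no clear difference from two of the five-membered rings: a 1.7-fold higher number from compound 3 to compound 4 (0.23 log units; within the scatter) and a 1.8-fold higher number from compound 2 to compound 4 (0.24 log units; within the scatter). Only the comparison with furan-2-yl passes the scatter, with a 2.1-fold higher number from compound 1 to compound 4 (0.32 log units; beyond the scatter), and this step is modest. The larger ring therefore leaves all four compounds within a narrow span, and no sharp demand for ring size appears among these groups. Nothing measured here accounts for the modest step.

Open, from the compounds shown here alone, is whether the place of the ring nitrogen matters, which phenyl, pyridin-3-yl and pyridin-4-yl could test on the shared core. Also open, going by these compounds, is how this position responds to groups other than aromatic rings, such as an amine or a carboxylic acid.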